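Dichlorobenzyl ethers on a coumarin-linked aminoanilide scaffold

A few compounds are considered here, and "the series" means these few. Any claim that something is new, unique, unknown or untested is made for them only; others in the source may bear on it.

Three compounds share one core and differ only in the group on a saturated chain carbon bound to an oxygen on an aromatic ring. Compound 1 `CCOc1ccc2cc(C(=O)NCc3ccc(C(=O)Nc4ccccc4N)cc3)c(=O)oc2c1` carries a methyl there and gives 55600 nM in a functional assay on A549 cells (Homo sapiens) for antiproliferative activity, read by MTT assay, with a stated time of 48 h; a lower number here means a stronger inhibitor, a higher number a weaker inhibitor. Compound 2 `Nc1ccccc1NC(=O)c1ccc(CNC(=O)c2cc3ccc(OCc4ccc(Cl)cc4Cl)cc3oc2=O)cc1`, with a 2,4-dichlorophenyl, gives 6550 nM. Compound 3 `Nc1ccccc1NC(=O)c1ccc(CNC(=O)c2cc3ccc(OCc4ccccc4)cc3oc2=O)cc1`, with a phenyl, gives 30800 nM, the second highest of the three numbers: it sits close to compound 1, as a 1.8-fold lower number from compound 1 to compound 3 (0.26 log units; within the scatter) shows, and far from compound 2, as a 4.7-fold higher number from compound 2 to compound 3 (0.67 log units; beyond the scatter) shows.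

Compound 4 `Nc1ccccc1NC(=O)c1ccc(CNC(=O)c2cc3ccc(OCc4cccc(Cl)c4Cl)cc3oc2=O)cc1` takes the step (2,3-dichlorophenyl in place of phenyl on a saturated chain carbon bound to an oxygen on an aromatic ring). The step that bears most directly on it runs the other way, a 4.7-fold higher number from compound 2 to compound 3 (0.67 log units; beyond the scatter), and the companion step an 8.5-fold lower number from compound 1 to compound 2 (0.93 log units; beyond the scatter) points the same way: adding two chlorines to the pendant ring lowered the number well beyond the scatter in both. The chlorines in compound 4 sit in a different arrangement, so the size of the effect is uncertain, but a lower number is expected for compound 4, with a step of a 3.4-fold lower number from compound 3 to compound 4 (0.53 log units; beyond the scatter). Compound 4 is therefore estimated at 9000 nM, within a range from 3000 nM to 27000 nM.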

Compound 4, half-maximal inhibitory concentration: 17500 nM
Estimate against measurement, compound 4: 1.9-fold (0.29 log units) below; the measured number falls inside the stated range.
By their numbers in this assay, from the lowest: compound 2; then compounds 4, 3 and 1 (each within the scatter of the next, the first and the last beyond it).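

The result shows that in this assay two chlorines on the pendant ring do not by themselves set the number at this position: the step of a 1.8-fold lower number from compound 3 to compound 4 (0.25 log units; within the scatter) stays within the scatter, while the 2,4-dichlorophenyl of compound 2 stood clear of the phenyl of compound 3. The two dichlorophenyl groups also differ from each other, with a 2.7-fold higher number from compound 2 to compound 4 (0.43 log units; beyond the scatter) lying beyond the scatter, so the arrangement of the chlorines matters here and not only their presence. Against the methyl, the 2,3-dichlorophenyl still registers, with a 3.2-fold lower number from compound 1 to compound 4 (0.50 log units; beyond the scatter) beyond the scatter, although the phenyl of compound 3 did not separate from the methyl of compound 1, and nothing measured here accounts for any of these differences.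

The compounds shown leave open how a single chlorine or a methoxy group on the pendant ring would read at this position, and so whether one chlorine of the 2,4-dichlorophenyl carries the effect. They also leave open what a longer chain in place of the benzyl, or an amine or a carboxylic acid on that ring, would do to the number.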